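Swapping the Chain End of a Benzamide Agonist

The source may report more compounds than this note shows. Statements on the series, on what has been measured and on what is new or still open speak of the compounds shown alone.

Three compounds have been measured in a functional assay on HEK293 cells for agonist activity at 5-hydroxytryptamine receptor 4 (Homo sapiens), read by cAMP accumulation; a lower number here means that less compound is needed, a higher number that more compound is needed for the effect:
Compound 1, `CC(C)n1c(=O)n(C(=O)NCC2CCNCC2)c2ccccc21`, gives 15.9 nM.
Compound 2, `CCN1CCC(NC(=O)c2cc(Cl)c(N)cc2OC)CC1`, gives 79.4 nM.
Compound 3, `COc1cc(N)c(Cl)cc1C(=O)NC1CCN(CCCCCN2C(=O)c3ccccc3C2=O)CC1`, gives 5.01 nM.

Compound 3 stands lowest of the three numbers. Compound 1 is nearest to it and compound 2 furthest from it, and both of those gaps lie beyond the usual scatter of this assay. Compound 2 and compound 3 share the same benzamide core, differing in what hangs on the ring nitrogen of the saturated ring.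

Compound 4, `COc1cc(N)c(Cl)cc1C(=O)NC1CCN(CCCCCCCCN2CCCCC2)CC1`, keeps that core and changes only the far end of the chain: a group of 9 heavy atoms (8 carbon, 1 nitrogen; one six-membered non-aromatic ring with 1 hetero atom) in place of a group of 11 heavy atoms (8 carbon, 1 nitrogen, 2 oxygen; one five-membered non-aromatic ring with 1 hetero atom, one six-membered aromatic ring of carbon only), on a saturated chain carbon, five bonds along the chain from an amine nitrogen in a ring. For the measured compounds named here, no pair of measured compounds differs in a single place, so the data give no direct yardstick for a change of this kind. The step from compound 3 to compound 4 in this assay is therefore expected to be modest, a 2.0-fold higher number from compound 3 to compound 4 (0.30 log units; within the scatter), leaning towards a somewhat higher number but possibly staying within the scatter. Compound 4 is estimated at 10 nM, with a range from 2 nM to 50 nM.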

Compound 4, half-maximal effective concentration: 3.16 nM
Estimate against measurement, compound 4: 3.2-fold (0.50 log units) above; the measured number falls inside the stated range.
By their numbers in this assay, from the lowest: compounds 4 and 3 (each within the scatter of the next); then compound 1; then compound 2.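

Replacing the group with the aromatic ring by 3-(piperidin-1-yl)propyl, on a saturated chain carbon, five bonds along the chain from an amine nitrogen in a ring, gives a 1.6-fold lower number from compound 3 to compound 4 (0.20 log units; within the scatter) in this assay. For the compounds shown here, this is the first comparison here of compounds that differ in one place, and it shows that the chain end can carry either of two quite different groups with no difference beyond the scatter, so an aromatic ring at this end is not needed for a low number in this pair. Nothing at hand explains why the two chain ends read alike.

As far as these compounds go, it remains open how a carboxylic acid or a simple primary amine at the chain end would read. From the compounds shown here alone, the effect of a shorter or longer chain between the saturated ring and the chain end, and of the same swap on the core of compound 1, also remains open.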